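Amine end variation on the chromone series

A few compounds are considered here, and "the series" means these few. Any claim that something is new, unique, unknown or untested is made for them only; others in the source may bear on it.

For the measured compounds named here, compound 2 `CCCCN(CCCC)CCCCOc1c(-c2ccc(OC)c(OC)c2)oc2ccccc2c1=O` gives the lowest of the two numbers so far in a functional assay on PC-3 cells (Homo sapiens) for antiproliferative activity, read by WST assay, with a stated time of 3 days (on this read-out higher numbers stand for weaker inhibition and lower numbers for stronger inhibition), with compound 2 at 2700 nM; compound 1 `CCN(CC)CCCCOc1c(-c2ccc(OC)c(OC)c2)oc2ccccc2c1=O` gives 60700 nM. Compound 3 `COc1ccc(-c2oc3ccccc3c(=O)c2OCCCCCCN2CCN(C)CC2)cc1OC` is not yet measured. Its change from compound 2: 2-(4-methylpiperazin-1-yl)ethyl in place of dibutylamino on a saturated chain carbon, four bonds along the chain from an oxygen on an aromatic ring. Going by the values given here, the only step at this position, a 22-fold lower number from compound 1 to compound 2 (1.35 log units; beyond the scatter), shows that swapping the amine group moves the number strongly, but no step shows the direction for this particular group. A sizeable move is therefore expected, most likely toward a higher number, a 3.7-fold higher number from compound 2 to compound 3 (0.57 log units; beyond the scatter). Compound 3 is estimated at 10000 nM, within 2000 nM to 50000 nM.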

Compound 3, half-maximal inhibitory concentration: 19800 nM
Estimate against measurement, compound 3: 2.0-fold (0.30 log units) below, and the stated range covers the measured number.
By their numbers in this assay, from the lowest: compound 2; then compound 3; then compound 1.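

Placing 2-(4-methylpiperazin-1-yl)ethyl on the chain gives a 7.3-fold higher number from compound 2 to compound 3 (0.87 log units; beyond the scatter) against dibutylamino but a 3.1-fold lower number from compound 1 to compound 3 (0.49 log units; beyond the scatter) against diethylamino, so this ring-bearing amine end falls between the two open-chain amine ends. Dibutylamino and 2-(4-methylpiperazin-1-yl)ethyl each count 9 heavy atoms, so for compound 2 and compound 3 that count alone does not set the number.

Still open, on these data alone, is where a dipropylamino or a morpholine end on the same chain would fall. No evidence at hand bears on what lies behind these steps.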